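A few compounds are considered here, and "the series" means these few. Any claim that something is new, unique, unknown or untested is made for them only; others in the source may bear on it.

Compound 1, `Cc1cc(O)c(C(=O)/C=C/c2ccc(OCc3ccccc3)cc2)c(-c2ccccc2)c1C(=O)/C=C/c1ccc(OCc2ccccc2)cc1`, gives 10000 nM in a functional assay on MDA-MB-231 cells (Homo sapiens) for cytotoxicity, read by MTT assay, with a stated time of 24 h; a lower number here means a stronger inhibitor, a higher number a weaker inhibitor. Compound 2, `Cc1cc(O)c(C(=O)/C=C/c2ccc(OCc3ccccc3)cc2)c(-c2ccc(Br)cc2)c1C(=O)/C=C/c1ccc(OCc2ccccc2)cc1`, carries bromo in place of hydrogen on an aromatic carbon and gives 20000 nM in this assay, so that the step of a 2.0-fold higher number from compound 1 to compound 2 (0.30 log units; within the scatter) stays within the scatter. Compound 3, `Cc1cc(O)c(C(=O)/C=C/c2ccc(Br)cc2)c(-c2ccccc2)c1C(=O)/C=C/c1ccc(Br)cc1`, differs from compound 1 in more than one place, and the difference between the two cores is not broken down here; in this assay compound 3 gives 10000 nM, level with compound 1 at the digits printed and within the scatter of compound 2. Compound 4, `Cc1cc(O)c(C(=O)/C=C/c2ccc(Br)cc2)c(-c2ccc(Br)cc2)c1C(=O)/C=C/c1ccc(Br)cc1`, has not been measured in this assay. Going by the values given here, it differs from compound 3 by bromo in place of hydrogen on an aromatic carbon, the same change as the one from compound 1 to compound 2, made at the same place. Because the step of a 2.0-fold higher number from compound 1 to compound 2 (0.30 log units; within the scatter) was small, the step from compound 3 to compound 4 is expected to be of similar size, a 1.5-fold higher number from compound 3 to compound 4 (0.18 log units; within the scatter), resting only on that single earlier example. On this basis compound 4 is estimated at 15000 nM in this assay, with a likely range from 7000 nM to 35000 nM.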

Compound 4, half-maximal inhibitory concentration: 18000 nM
Beside the measured number, compound 4's estimate is 1.2-fold (0.08 log units) below it; the range from low to high includes it.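

Replacing phenyl with 4-bromophenyl on the core of compound 3 gives a 1.8-fold higher number from compound 3 to compound 4 (0.26 log units; within the scatter) in this assay, and the same replacement on the core of compound 1 gives a step that cannot be told from it: the same change on two cores in this assay, a 2.0-fold higher number (0.30 log units; within the scatter) from compound 1 to compound 2 and a 1.8-fold higher number (0.26 log units; within the scatter) from compound 3 to compound 4, 1.1-fold (0.05 log units) apart, within the scatter of two such steps. Within these two pairs, then, the change carries from one core to the other without any visible difference, and a small step on one core went with a small step on the other. It does not show that bromo itself moves the number, since both steps lie within the scatter, and two pairs say nothing about how the change would behave on a core unlike these two.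

At this place on the ring the compounds shown carry only hydrogen or bromo, so it stays open how a chloro, a methoxy, an amine or a carboxylic acid there would read in this assay. Also open, from the compounds shown here alone, is whether any group at this place would give a step beyond the scatter on either core.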